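A few compounds are considered here, and "the series" means these few. Any claim that something is new, unique, unknown or untested is made for them only; others in the source may bear on it.

Compound 1 `Cc1cccc(Nc2nccc(-c3ccsc3)n2)c1`: 3800 nM
Compound 2 `CCc1cccc(Nc2nccc(-c3ccsc3)n2)c1`: 1100 nM
Compound 3 `COc1cccc(Nc2nccc(-c3ccsc3)n2)c1`: 1800 nM

In a functional assay for inhibition, with Homo sapiens as the target (on this read-out lower numbers stand for stronger inhibition and higher numbers for weaker inhibition), compound 1 gives the highest of the three numbers; the two steps away from it are a 2.1-fold lower number from compound 1 to compound 3 (0.32 log units; beyond the scatter) and a 3.5-fold lower number from compound 1 to compound 2 (0.54 log units; beyond the scatter), while compound 2 and compound 3 differ by a 1.6-fold higher number from compound 2 to compound 3 (0.21 log units; within the scatter). Compound 4 `Cc1cccc(Nc2nccc(-c3ccc[nH]3)n2)c1` differs from compound 1 by 1H-pyrrol-2-yl in place of thiophen-3-yl on an aromatic carbon. Going by the values given here, none of the measured steps touches this part of the shared core: all three vary the group on the other ring, so no measured step bears on the change, and its direction cannot be read from the data. Compound 4 is therefore expected to stay near compound 1, with the step of a 1.3-fold lower number from compound 1 to compound 4 (0.10 log units; within the scatter) not beyond the scatter. The estimate for compound 4 is 3000 nM, within 800 nM to 12000 nM.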

Compound 4, half-maximal inhibitory concentration: 8500 nM
Compound 4: the middle estimate sits 2.8-fold (0.45 log units) below what was measured; the measured number falls inside the stated range.
By their numbers in this assay, from the lowest: compounds 2 and 3 (each within the scatter of the next); then compound 1; then compound 4.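

Compound 1, compound 2 and compound 3 vary only the group on the other ring, whereas compound 4 shows that the position on the shared core also affects the read-out in this assay. Replacing thiophen-3-yl with 1H-pyrrol-2-yl gives a 2.2-fold higher number from compound 1 to compound 4 (0.35 log units; beyond the scatter), a modest weakening of inhibition. Nothing available explains this step. The compounds shown leave open how thiophen-2-yl or furan-3-yl would read at this position. They also leave open whether the ethyl group of compound 2 would keep its step alongside 1H-pyrrol-2-yl.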